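A few compounds are considered here, and "the series" means these few. Any claim that something is new, unique, unknown or untested is made for them only; others in the source may bear on it.

Compound 1 `COc1ccc(-c2cnc3nc(N)nc(N4CCN(c5cc(Cl)cc(Cl)c5)CC4)c3n2)cc1OC` is the starting point of this comparison. In a functional assay on cells (T-cell, Homo sapiens) for inhibition (on this read-out higher numbers stand for weaker inhibition and lower numbers for stronger inhibition), compound 1 gives 3400 nM, the lowest of the two numbers that were actually measured here. Its closest companion is compound 3 `COc1ccc(-c2cnc3nc(N)nc(NCc4cccs4)c3n2)cc1OC`, which in this assay gives 4100 nM, a difference that lies within the usual scatter. Compound 2 `CCOc1nc(N)nc2ncc(-c3ccc(OC)cc3)nc12` reached only a limit of this assay, recorded as > 10000 nM (the limit of > 10000 nM in this assay, at which 1 of the 3 values shown sits).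

Compound 4 `COc1ccc(-c2cnc3nc(N)nc(N4CCN(C(=O)COc5ccc(Cl)cc5)CC4)c3n2)cc1OC` has not yet been measured. It differs from compound 1 in one place: ((4-chlorophenoxy)methyl)carbonyl in place of 3,5-dichlorophenyl on an amine nitrogen in a ring. Among the measured compounds shown here, no measured step between two compounds of this kind is available, so the expectation rests on the single number for compound 1. Compound 4 is expected to change little, with a step of a 1.5-fold higher number from compound 1 to compound 4 (0.17 log units; within the scatter), toward a value of 5000 nM, between 1500 nM and 15000 nM.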

Compound 4, half-maximal inhibitory concentration: 0.5 nM
Compound 4: the middle estimate sits 10000-fold (4.00 log units) above what was measured; the measured number lies below the stated range.
By their numbers in this assay, from the lowest: compound 4; then compounds 1 and 3 (each within the scatter of the next). At a limit, above all of these: compound 2.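

Replacing 3,5-dichlorophenyl with ((4-chlorophenoxy)methyl)carbonyl on the amine nitrogen in a ring gives in this assay a 6800-fold lower number from compound 1 to compound 4 (3.83 log units; beyond the scatter). This shows that inhibition can depend very strongly on the group at this position, which compound 1 alone could not reveal. Nothing given here accounts for the size of this step.

The change alters the carbonyl, the oxygen link and the chlorine pattern together, and the step cannot separate them. As far as these compounds go, whether a simple acetyl or a benzoyl group on this nitrogen would retain such strong inhibition remains open.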